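Replacing a Pentyl Chain With Cyclohexyl on the Urea

The source may report more compounds than this note shows. Statements on the series, on what has been measured and on what is new or still open speak of the compounds shown alone.

Compound 1, `CCCCNC(=O)Nc1c(OCCCn2cnc(-c3ccccc3)c2)cccc1N(C)C`, in an assay on aorta for inhibition of acyl-CoA:cholesterol acyltransferase (Oryctolagus cuniculus) (on this read-out higher numbers stand for weaker inhibition and lower numbers for stronger inhibition), gives 810 nM.
Compound 2, `CCCCCNC(=O)Nc1c(OCCCn2cnc(-c3ccccc3)c2)cccc1N(C)C`, in this assay gives 160 nM.

Going by the values given here, on these two numbers compound 2 stands lowest, meaning it is the stronger inhibitor of the pair; the only other compound, compound 1, gives a higher number, and that gap lies beyond the scatter. Compound 3 is `CN(C)c1cccc(OCCCn2cnc(-c3ccccc3)c2)c1NC(=O)NC1CCCCC1`. It differs from compound 2 in one place: cyclohexyl in place of pentyl on an amide-type nitrogen. Among the compounds with values here, only one measured step exists to guide an expectation, and it bears on this change indirectly: a 5.1-fold lower number from compound 1 to compound 2 (0.70 log units; beyond the scatter). Within the data shown here, that step added one carbon to an open chain; the present change instead puts a ring in place of the chain, and no measured pair shows what such a ring does here. The expected outcome in this assay is therefore a small step, a 1.3-fold lower number from compound 2 to compound 3 (0.12 log units; within the scatter), that likely stays within the scatter. The estimate for compound 3 is 120 nM, expected to fall between 40 nM and 400 nM.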

Compound 3, half-maximal inhibitory concentration: 1070 nM
Compound 3: the middle estimate sits 8.9-fold (0.95 log units) below what was measured; measured number outside the range, above it.
By their numbers in this assay, from the lowest: compound 2; then compounds 1 and 3 (each within the scatter of the next).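

At this amide-type nitrogen, a ring does not act like an open chain with a similar carbon count: in this assay, cyclohexyl in place of pentyl gives a 6.7-fold higher number from compound 2 to compound 3 (0.83 log units; beyond the scatter) even though cyclohexyl has 6 carbons and pentyl has 5. Carbon count alone therefore does not follow the numbers, although the earlier chain step had given a 5.1-fold lower number from compound 1 to compound 2 (0.70 log units; beyond the scatter) when one carbon was added; the cyclohexyl and butyl compounds are separated by only a 1.3-fold higher number from compound 1 to compound 3 (0.12 log units; within the scatter), so the gain seen with pentyl is absent from compound 3. The data shown offer no evidence on what lies behind this difference between the ring and the chain.

Still open, on these data alone, is whether a longer chain, such as hexyl or heptyl, would continue the trend seen from butyl to pentyl or whether pentyl is already near the best length. As far as these compounds go, it is also open whether the loss belongs to rings at this nitrogen in general, which cyclopentyl or cyclohexylmethyl could test, or to the cyclohexyl group alone.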